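The source may report more compounds than this note shows. Statements on the series, on what has been measured and on what is new or still open speak of the compounds shown alone.

In an ADME assay on Vero cells (Chlorocebus sabaeus) for cytotoxicity, read by MTT assay, with a stated time of 72 h (on this read-out higher numbers stand for lower toxicity in this test and lower numbers for higher toxicity in this test), compound 3 `C[C@]1(CN2CCc3nc(-c4cccc(Cl)c4F)ccc3C2)Cn2cc([N+](=O)[O-])nc2O1` gives > 32 ug/mL, which is a limit and not a number. Compound 1 `C[C@]1(CN2CCc3nc(-c4ccccc4)ccc3C2)Cn2cc([N+](=O)[O-])nc2O1` gives > 32 ug/mL, also a limit. For compound 2 `C[C@]1(CN2CCc3nc(N4CCCCC4)ccc3C2)Cn2cc([N+](=O)[O-])nc2O1` the entry is "not determined" (no result reported), so it adds nothing to the comparison. That leaves compound 3 at the limit of > 32 ug/mL in this assay, at which 2 of the 3 values shown sit.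

Compound 4 `C[C@]1(CN2CCc3nc(-c4ccc(Cl)cc4F)ccc3C2)Cn2cc([N+](=O)[O-])nc2O1` keeps the same atoms as compound 3, joined differently: 4-chloro-2-fluorophenyl in place of 3-chloro-2-fluorophenyl on an aromatic carbon. The 4-chloro-2-fluorophenyl enters in place of 3-chloro-2-fluorophenyl on an aromatic carbon, next to the ring nitrogen.

Among the measured compounds shown here, the one measured step that bears on this change is a step that the two limits leave unreadable from compound 1 to compound 3, so it offers no size to carry over. It does show a change of substituents on that phenyl leaving the reading at a limit, and on that slender basis no shift beyond the scatter is expected in this assay. The expected step is a step that the limit leaves unreadable from compound 3 to compound 4. Compound 4 is estimated at 40 ug/mL, with an expected range from 20 ug/mL to 64 ug/mL.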

Compound 4, half-maximal cytotoxic concentration: > 32 ug/mL
Compound 4: a limit, no number; the forecaster's own chance of this, stated with the estimate: 80%; the middle value is on the limit's open side.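

In this assay, among the compounds shown here, no step among compound 1, compound 3 and compound 4 can be read, since each gives only a limit: the limit of > 32 ug/mL in this assay, at which 3 of the 4 values shown sit. The compounds shown leave open where their true values lie, and whether 3-chloro-2-fluorophenyl, 4-chloro-2-fluorophenyl and phenyl differ in this test at all.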